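The source may report more compounds than this note shows. Statements on the series, on what has been measured and on what is new or still open speak of the compounds shown alone.

Measured in an ADME assay on HeLa cells (Homo sapiens) for cytotoxicity, read by crystal violet staining, with a stated time of 72 h; on this read-out higher numbers stand for lower toxicity in this test and lower numbers for higher toxicity in this test:
- compound 1 `CCOC(=O)c1cc(CCCOc2ccc(-c3noc(C(F)(F)F)n3)cc2)on1`: > 100000 nM
- compound 2 `CCOC(=O)c1cc(CCCOc2ccc(-c3noc(C(F)(F)F)n3)cc2C(F)(F)F)on1`: 28400 nM
- compound 3 `Cc1cc(-c2noc(C(F)(F)F)n2)cc(C)c1OCCCc1cc(C(=O)OC(C)C)no1`: 17900 nM

The value of compound 1 is a limit of the assay and not a number. Compound 2 gives 28400 nM and compound 3 gives 17900 nM, and these two values lie within the usual scatter of each other.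

Compound 4 `Cc1cc(-c2noc(C(F)(F)F)n2)cc(C)c1OCCCc1cc(C(N)=O)no1` differs from compound 3 at one place: amino in place of isopropoxy on a carbonyl carbon. Amino in place of isopropoxy on a carbonyl carbon turns isopropoxycarbonyl into carbamoyl.

Going by the values given here, no measured step touches this carbonyl carbon. Among the compounds with values here, the only measured step, an at least 3.5-fold lower number from compound 1 to compound 2 (0.54 log units; beyond the scatter), is trifluoromethyl in place of hydrogen on an aromatic carbon, so it serves only as a loose guide to how far one change can move the number. A modest step toward a higher number is expected, but this is a weak lean. It rests only on compound 1, whose value of > 100000 nM is a limit.

The estimated change is a 2.2-fold higher number from compound 3 to compound 4 (0.35 log units; beyond the scatter), and a result within the scatter would fit as well. For compound 4 the expected value is 40000 nM, with an estimated range of 12000 nM to 100000 nM.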

Compound 4, half-maximal cytotoxic concentration: > 100000 nM
Compound 4: only a limit was reported; the forecaster's own chance of this, stated with the estimate: 30%; middle value at least 2.5-fold (0.39 log units) from the limit.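

In this assay, amino in place of isopropoxy on the carbonyl carbon, which turns isopropoxycarbonyl into carbamoyl, gives an at least 5.5-fold higher number from compound 3 to compound 4 (0.74 log units; beyond the scatter). Going by these compounds alone, the only earlier step touched an aromatic carbon, so this shows that the number also responds to a change on the carbonyl carbon, here in the direction of lower toxicity in this test. Compound 4 gives > 100000 nM, which is a limit of the assay and not a number, so the step has a lower bound but no known size: the limit of > 100000 nM in this assay, at which 2 of the 4 values shown sit.

The compounds shown leave open where other groups on this carbonyl carbon would fall, such as methylamino, dimethylamino or the hydroxy group of a carboxylic acid. They also leave open whether carbamoyl in place of ethoxycarbonyl on compound 2 would move the number the same way.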